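Adding a Methoxy Group to the Benzyl Arm of Compound 3

The source may report more compounds than this note shows. Statements on the series, on what has been measured and on what is new or still open speak of the compounds shown alone.

Three compounds have numbers in an assay on membranes from HEK293 cells for displacement of a labelled ligand from Translocator protein (Homo sapiens), read by scintillation counting, with a stated time of 90 min; a lower number here means a stronger inhibitor, a higher number a weaker inhibitor. Compound 1 `C#CCN(C)C(=O)c1cc2cc(C)ccc2n1Cc1ccc(OC)nc1` is measured only as a limit, > 10000 nM, and not as a number. Compound 2 `COc1ccc(CN(C(C)=O)c2cc(C)cc(C)c2)cc1` gives 500 nM, and compound 3 `CCN(CC)C(=O)CN(Cc1ccccc1)c1cc(C)cc(C)c1` gives 1010 nM. Compound 3 therefore has the highest of the two numbers that are known, with compound 2 the nearest and beyond the usual scatter from it; nothing links compound 3 to the limit of compound 1 beyond the two values themselves.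

Compound 4 `CCN(CC)C(=O)CN(Cc1ccc(OC)cc1)c1cc(C)cc(C)c1` is not yet measured. It differs from compound 3 in one place: methoxy in place of hydrogen on an aromatic carbon, on an aromatic carbon of a six-membered aromatic ring of carbon only, para to a large group, so that phenyl becomes 4-methoxyphenyl. Within the data shown here, no measured step of this kind stands among the three compounds, so the size of the step is open. A modest move toward a lower number is expected, since compound 2, which carries the same 4-methoxyphenyl group, gives 500 nM, though it differs in more than one place. For compound 4 the expected step is a 1.4-fold lower number from compound 3 to compound 4 (0.16 log units; within the scatter). Compound 4 is estimated at 700 nM, within the range 250 nM to 2000 nM.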

Compound 4, inhibition constant: 1200 nM
Compound 4: the middle estimate sits 1.7-fold (0.23 log units) below what was measured; the measured number falls inside the stated range.
By their numbers in this assay, from the lowest: compound 2; then compounds 3 and 4 (each within the scatter of the next). At a limit, above all of these: compound 1.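

In this assay the first step read at this position is a 1.2-fold higher number from compound 3 to compound 4 (0.07 log units; within the scatter), so methoxy in place of hydrogen on an aromatic carbon, para to a large group, leaves compound 3 and compound 4 within the scatter of each other. With 4-methoxyphenyl present in both compounds, the group on the nitrogen does separate them: (diethylcarbamoyl)methyl in place of acetyl on a nitrogen on an aromatic ring gives a 2.4-fold higher number from compound 2 to compound 4 (0.38 log units; beyond the scatter), a modest step beyond the scatter. Nothing shown gives a cause for either step.

From the compounds shown here alone, whether an amine, a carboxylic acid or a longer alkoxy chain at this para place would give a step beyond the scatter remains open. Going by these compounds, it is also open whether phenyl to 4-methoxyphenyl would read the same with acetyl on the nitrogen.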